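The compounds below may be only part of what the source reports. "The series", "measured", "known", "first", "only" and "open" are said of these compounds alone.

Compound 2 `CCOc1cc(C(C)(C)C)ccc1C1=NC(c2ccc(Cl)cc2)C(c2ccc(Cl)cc2)N1C(=O)N1CCN(CCCCC(=O)NO)CC1` gives 170 nM in an assay on isolated protein for inhibition of E3 ubiquitin-protein ligase Mdm2 (Homo sapiens), read by fluorescence polarization, with a stated time of 30 min; on this read-out lower numbers stand for stronger inhibition and higher numbers for weaker inhibition. Compound 1 `CCOc1cc(C(C)(C)C)ccc1C1=NC(c2ccc(Cl)cc2)C(c2ccc(Cl)cc2)N1C(=O)N1CCN(CCCCCC(=O)NO)CC1` gives 170 nM, and the step of no change at the digits printed from compound 1 to compound 2 (within the scatter) stays within the scatter, so compound 2 stands level with compound 1. Compound 3 `CCOc1cc(C(C)(C)C)ccc1C1=NC(c2ccc(Cl)cc2)C(c2ccc(Cl)cc2)N1C(=O)N1CCN(c2ncc(C(=O)NO)cn2)CC1` differs from compound 2 by 5-(hydroxycarbamoyl)pyrimidin-2-yl in place of 4-(hydroxycarbamoyl)butyl on an amine nitrogen in a ring. Among the compounds with values here, the single measured step, from compound 1 to compound 2, shortened the same tail and moved nothing, but it offers no direct guide to a ring in place of a chain. The expected step of a 1.2-fold higher number from compound 2 to compound 3 (0.07 log units; within the scatter) is therefore small, in no settled direction, with wide uncertainty. Compound 3 is estimated to give 200 nM in this assay, with a range from 50 nM to 800 nM.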

Compound 3, inhibition constant: 1050 nM
Beside the measured number, compound 3's estimate is 5.3-fold (0.72 log units) below it, and the stated range ends below it.
By their numbers in this assay, from the lowest: compounds 1 and 2 (each within the scatter of the next); then compound 3.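

In this assay the 5-(hydroxycarbamoyl)pyrimidin-2-yl group on the amine nitrogen in a ring gives a 6.2-fold higher number from compound 2 to compound 3 (0.79 log units; beyond the scatter) against 4-(hydroxycarbamoyl)butyl and a 6.2-fold higher number from compound 1 to compound 3 (0.79 log units; beyond the scatter) against 5-(hydroxycarbamoyl)pentyl. Within the data shown here, this is the first change at this position to move the number beyond the scatter: the two chains stand level, while this aromatic ring bearing the same hydroxycarbamoyl group does worse. No measured evidence accounts for the difference. Still open, going by these compounds, is whether a phenyl ring bearing hydroxycarbamoyl behaves like the pyrimidine, and whether a carboxylic acid in place of hydroxycarbamoyl on the chain holds the number.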